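Cyclohexyl to 2-chlorophenyl at the chain carbon

The compounds below may be only part of what the source reports. "The series", "measured", "known", "first", "only" and "open" are said of these compounds alone.

For the measured compounds named here, compound 1 `O=C(O)c1ccccc1-c1ccc(CCc2ncc(CC3CCCCC3)[nH]2)cc1` gives 41 nM in an in vitro functional assay on cells for agonist activity at Bombesin receptor subtype-3 (Homo sapiens), read by luminescence and calcium flux (on this read-out lower numbers stand for an effect already at smaller amounts and higher numbers for an effect only at larger amounts of compound), and stands lowest of the three numbers measured so far. Going by the values given here, compound 2 `O=C(O)c1ccccc1-c1ccc(CCc2ncc(CC3CCCC3)[nH]2)cc1` gives 133 nM in this assay; the only single-point step known is a 3.2-fold higher number from compound 1 to compound 2 (0.51 log units; beyond the scatter). Compound 3 `CCCCc1cnc(C(CCCC)Cc2ccc(-c3ccccc3C(=O)O)cc2)[nH]1` differs from compound 1 at several places. In this assay compound 3 gives 2660 nM, the highest number of the three.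

Compound 4 `O=C(O)c1ccccc1-c1ccc(CCc2ncc(Cc3ccccc3Cl)[nH]2)cc1` has not been measured. Relative to compound 1 the change is 2-chlorophenyl in place of cyclohexyl on a saturated chain carbon bound to an aromatic carbon. The step from compound 1 to compound 2, a 3.2-fold higher number from compound 1 to compound 2 (0.51 log units; beyond the scatter), is the only one at the same place; it shows that the saturated ring at this carbon is sensitive to change. Among the compounds with values here, no measured pair shows a saturated ring exchanged for an aromatic one, nor a chlorine introduced, so the direction rests on that one step alone. The expectation is a modest increase in the number, a 2.9-fold higher number from compound 1 to compound 4 (0.47 log units; beyond the scatter), with wide uncertainty. Compound 4 is therefore estimated at 120 nM in this assay, within a range of 30 nM to 500 nM.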

Compound 4, half-maximal effective concentration: 292 nM
For compound 4 the middle estimate is 2.4-fold (0.39 log units) below the measured one; measured number inside the range.
By their numbers in this assay, from the lowest: compound 1; then compound 2; then compound 4; then compound 3.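

In this assay, 2-chlorophenyl in place of cyclohexyl on a saturated chain carbon bound to an aromatic carbon gives a 7.1-fold higher number from compound 1 to compound 4 (0.85 log units; beyond the scatter), so this position accepts an aromatic ring, but at a larger cost than the ring-size change seen earlier, a 3.2-fold higher number from compound 1 to compound 2 (0.51 log units; beyond the scatter). The comparison with the smaller saturated ring gives a 2.2-fold higher number from compound 2 to compound 4 (0.34 log units; beyond the scatter), which sets the three groups in one order from the lowest number: cyclohexyl, cyclopentyl, 2-chlorophenyl, with each step beyond the usual scatter. Nothing available explains this order.

Compound 4 changes the ring and adds a chlorine in one step, so the shift cannot be divided between the two, and a plain phenyl at this carbon would be needed to separate them. Also open, on these data alone, is whether any ring at this carbon is required at all, since an open alkyl chain such as n-hexyl in this same place, or a saturated ring carrying an amine, would test how far the trend seen with these three groups extends.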